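The source may hold more compounds than are shown below. What is called first, only, known or untested is meant among the compounds shown, and "the series" means these compounds.

Compound 3 `COc1cc(-c2nn(-c3cccc(NC(=O)Nc4cccc(C(F)(F)F)c4)c3)cc2-c2ccncc2)ccc1Cl` gives the lowest of the three numbers in a functional assay on HCC 2998 cells (Homo sapiens) for inhibition, read by sulforhodamine B assay, with a stated time of 48 h (a lower number here means a stronger inhibitor of growth, a higher number a weaker inhibitor of growth), at 3200 nM. Its nearest neighbour is compound 2 `COc1cc(-c2nn(-c3cccc(NC(=O)Nc4ccc(Cl)c(Cl)c4)c3)cc2-c2ccncc2)ccc1Cl`, which gives 6200 nM, a gap that is a 1.9-fold lower number from compound 2 to compound 3 (0.29 log units; within the scatter). Compound 1 `COc1cc(-c2nn(-c3cccc(NC(=O)c4cccc(C(F)(F)F)c4)c3)cc2-c2ccncc2)ccc1Cl` stands furthest away with 17600 nM, and the step of a 5.5-fold lower number from compound 1 to compound 3 (0.74 log units; beyond the scatter) lies well beyond the scatter.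

Compound 4 `COc1cc(-c2nn(-c3cccc(NC(=O)c4ccc(Cl)c(C(F)(F)F)c4)c3)cc2-c2ccncc2)ccc1Cl` is not yet measured. It differs from compound 3 by 4-chloro-3-(trifluoromethyl)phenyl in place of (3-(trifluoromethyl)phenyl)amino on a carbonyl carbon. The change bears on the same carbonyl carbon as the step from compound 1 to compound 3, where a (3-(trifluoromethyl)phenyl)amino in place of 3-(trifluoromethyl)phenyl gave a 5.5-fold lower number from compound 1 to compound 3 (0.74 log units; beyond the scatter), and as the step of a 2.8-fold lower number from compound 1 to compound 2 (0.45 log units; beyond the scatter). Compound 4 runs the other way, back to an aryl bound directly to the carbonyl carbon, so a higher number is expected in this assay, while the step of a 1.9-fold lower number from compound 2 to compound 3 (0.29 log units; within the scatter) suggests that the substituents on that aryl change little. The expected step is a 3.8-fold higher number from compound 3 to compound 4 (0.57 log units; beyond the scatter), and compound 4 is estimated at 12000 nM, between 5000 nM and 30000 nM.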

Compound 4, concentration for total growth inhibition: > 32500 nM
Compound 4 was reported as a limit; the forecaster's own chance of this, stated with the estimate: 5%; at least 2.7-fold (0.43 log units) between middle value and limit.
By their numbers in this assay, from the lowest: compounds 3 and 2 (each within the scatter of the next); then compound 1. At a limit, above all of these: compound 4.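

In this assay compound 4 gives > 32500 nM and this is a limit, not a number. An aryl bound directly to the carbonyl carbon in place of the arylamino group gives an at least 10-fold higher number from compound 3 to compound 4 (1.00 log units; beyond the scatter) and an at least 5.2-fold higher number from compound 2 to compound 4 (0.71 log units; beyond the scatter) and both steps lie beyond the scatter even as floors. The earlier contrast at this carbonyl carbon therefore holds for a second such aryl: compound 1 and compound 4 both give higher numbers than compound 2 and compound 3, and no compound shown goes against this.

The step of an at least 1.8-fold higher number from compound 1 to compound 4 (0.26 log units; that floor lies within the scatter) has a floor within the scatter and cannot be read, which leaves open whether the chloro changes anything. Also open, as far as these compounds go, is how this carbonyl carbon behaves with a benzyl group or a benzyloxy group in place of the aryl or arylamino group.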